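The source may hold more compounds than are shown below. What is called first, only, known or untested is meant among the compounds shown, and "the series" means these compounds.

Compound 2 (`CCn1c(-c2cnc(C)nc2)nc2c(N[C@H]3CCN(C(=O)[C@H]4C[C@@H](OC)C4)C3)ncnc21`) was measured in an ADME assay (Canis lupus familiaris, strain Beagle) for pharmacokinetics (on this read-out lower numbers stand for narrower distribution and higher numbers for wider distribution into tissues), and gave 1.5 L/kg. The other measured compound, compound 1 (`CCC(=O)N1CC[C@H](Oc2ncnc3c2nc(-c2cnc(C)nc2)n3CC)C1`), gave 1.9 L/kg in this assay; the two numbers lie within the scatter of each other, so neither stands apart. Compound 3 (`CCn1c(-c2cnc(C)nc2)nc2c(N[C@H]3CCN(C(=O)C4CC4)C3)ncnc21`) has not been measured. It differs from compound 2 by cyclopropyl in place of 3-methoxycyclobutyl on a carbonyl carbon. Among the measured compounds shown here, no step of this kind is known here, so the size of the change can only be estimated. Compound 3 is expected to move by no change at the digits printed from compound 2 to compound 3 (within the scatter), no more than the scatter. Compound 3 is therefore estimated at 1.5 L/kg, between 0.9 L/kg and 2.5 L/kg.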

Compound 3, volume of distribution: 1.5 L/kg
Beside the measured number, compound 3's estimate shows no gap at the digits printed; the measured number falls inside the stated range.
By their numbers in this assay, from the lowest: compounds 2, 3 and 1 (each within the scatter of the next).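

In this assay, among the compounds shown here, cyclopropyl in place of 3-methoxycyclobutyl on a carbonyl carbon brings no change at the digits printed from compound 2 to compound 3 (within the scatter) as the first step that can be read at this position. The read-out therefore stays within the scatter when the methoxy group and the four-membered ring give way to the smaller three-membered ring. From the compounds shown here alone, whether a more different group on that carbonyl carbon, such as an aminomethyl group or a carboxylic acid, would shift the volume of distribution remains open. The data hold no measurement that would explain this result.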